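Ribose series: benzyl to butyl at the ring nitrogen

The source may hold more compounds than are shown below. What is called first, only, known or untested is meant among the compounds shown, and "the series" means these compounds.

Measured compounds in this set:
- compound 1, `COc1ccc(Cn2c(=O)n(C3OC(CO)[C@@H](O)[C@H]3O)c3nc(N)nc(O)c32)cc1`, 14%
- compound 2, `C=CCSc1nc2c(O)nc(N)nc2n1C1OC(CO)[C@@H](O)[C@H]1O`, 57%
- compound 3, `C=CCn1c(=S)n(COCCO)c2nc(N)nc(O)c21`, 7%

In a functional assay on the whole organism with Mus musculus as the target (a lower number here means a smaller maximal response, a higher number a larger maximal response), compound 1 gives 14%, the second highest of the three numbers. Compound 3 gives 7%, which lies within the scatter of compound 1, so no order between the two can be read. Compound 2 gives 57%, well beyond the scatter above compound 1; compound 2 differs from compound 1 in more than one place, so that gap cannot be tied to a single change.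

Compound 4, `CCCCn1c(=O)n(C2OC(CO)[C@@H](O)[C@H]2O)c2nc(N)nc(O)c21`, has not been measured in this assay. It differs from compound 1 as follows: propyl in place of 4-methoxyphenyl on a saturated chain carbon bound to an aromatic nitrogen. Within the data shown here, no single-point step between measured compounds exists here, so the size of this change is unknown from the data. Among the measured compounds shown here, the two compounds with a maximal response within scatter of each other, compound 1 and compound 3, both carry a small or medium substituent on the shared core and sit at the low end; compound 2 is the only high value and is not comparable by one change.

The step from compound 1 to compound 4 is expected to be small, with no clear direction beyond the scatter, a number 1 percentage points higher from compound 1 to compound 4 (within the scatter). Compound 4 is therefore estimated at 15%, with a range from 4% to 35%.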

Compound 4, largest response reached (reported as maximal response), in percent of the reference or control that the assay uses: 70%
The estimate for compound 4 lay 55 percentage points below the measured number, outside the stated range (above it).
By their numbers in this assay, from the lowest: compounds 3 and 1 (each within the scatter of the next); then compound 2; then compound 4.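

In this assay, among these compounds, the change from 4-methoxybenzyl to butyl gives a number 56 percentage points higher from compound 1 to compound 4 (beyond the scatter) and is the first step in the set that can be read at a single place. Among the compounds shown here, the substituent on a saturated chain carbon bound to an aromatic nitrogen therefore has a large bearing on the maximal response in the ribose series, which the earlier compounds, differing in more than one place, could not show. The change removes 8 heavy atoms, including one six-membered aromatic ring and 1 hydrogen-bond acceptor, and brings in 3 heavy atoms with no ring, so several differences travel together and no data here bear on which of them accounts for the step.

From the compounds shown here alone, it remains open whether the low value goes with the aromatic ring itself or with the methoxy group on it, a question that an unsubstituted benzyl and a cyclohexylmethyl at this place would separate. Also open, going by these compounds, is how the response runs with chain length, which a hexyl chain would test against the butyl of compound 4.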